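Solubility notes on the shared core: thiophene for dimethylaminophenyl

A few compounds are considered here, and "the series" means these few. Any claim that something is new, unique, unknown or untested is made for them only; others in the source may bear on it.

Compound 1 `Cc1cc(NCc2c[nH]cn2)n2nc(C)c(-c3ccccc3)c2n1` gives 14600 nM in a physicochemical assay for solubility, read by HPLC, using the shake flask method, measured as kinetic solubility, with a stated time of 2 h, at pH 7.4 (on this read-out lower numbers stand for lower solubility and higher numbers for higher solubility), and compound 2 `Cc1cc(NCc2nccs2)n2nc(C)c(-c3ccccc3)c2n1` gives 108000 nM. Going by the values given here, the single paired step, a 7.4-fold higher number from compound 1 to compound 2 (0.87 log units; beyond the scatter), lies on a saturated chain carbon bound to a nitrogen on an aromatic ring, not at the site changed here. Compound 3 `Cc1cc(NCc2ccccn2)n2ncc(-c3ccc(N(C)C)cc3)c2n1` reports only a limit in this assay, < 5000 nM, and so sits at the bottom of the numbers shown, as in the limit of < 5000 nM in this assay, at which 1 of the 3 values shown sits. Compound 4 `Cc1cc(NCc2ccccn2)n2ncc(-c3ccsc3)c2n1` differs from compound 3 as follows: thiophen-3-yl in place of 4-(dimethylamino)phenyl on an aromatic carbon. Among the compounds with values here, no measured step touches this position, so neither size nor direction can be read from the pairs in hand. Compound 4 is expected to come out at 8000 nM (range 3000 nM to 30000 nM). That estimate amounts to a step of an at least 1.6-fold higher number from compound 3 to compound 4 (0.20 log units; that floor lies within the scatter) taken from the limit of compound 3.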

Compound 4, solubility: 9000 nM
The estimate for compound 4 lay 1.1-fold (0.05 log units) below the measured number, and the stated range covers the measured number.
By their numbers in this assay, from the lowest: compounds 4 and 1 (each within the scatter of the next); then compound 2. At a limit, below all of these: compound 3.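

Thiophen-3-yl in place of 4-(dimethylamino)phenyl gives the first reading at this aromatic carbon, with an at least 1.8-fold higher number from compound 3 to compound 4 (0.25 log units; that floor lies within the scatter) in this assay for this change. From the compounds shown here alone, compound 3 stands at a limit, so this step is only a floor and its full size stays unknown: the limit of < 5000 nM in this assay, at which 1 of the 4 values shown sits. Whether the true step clears the usual scatter cannot be read.

Still open, going by these compounds, is how an amine or a carboxylic acid at this carbon would read in this assay on the shared core. Why the number moves also remains unresolved.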